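The source may hold more compounds than are shown below. What is called first, only, known or untested is meant among the compounds shown, and "the series" means these compounds.

In an ADME assay on microsomes from liver (Homo sapiens) for metabolic stability (on this read-out higher numbers stand for a longer-lived compound and lower numbers for a shorter-lived compound), compound 1 `COc1cc(OCc2cccc(-c3ccc(C#N)cn3)c2)c2cc(-c3cn4nc(OC)sc4n3)oc2c1` gives 1.57 h and compound 2 `COc1cc(OCc2cccc(-c3cnc(OC)cn3)c2)c2cc(-c3cn4nc(OC)sc4n3)oc2c1` gives 1.48 h while compound 3 `COc1ccc(-c2cccc(COc3cc(OC)cc4oc(-c5cn6nc(OC)sc6n5)cc34)c2)nc1` stands at 0.767 h on the same read-out. The two steps into compound 3 are a 1.9-fold lower number from compound 2 to compound 3 (0.29 log units; within the scatter) and a 2.0-fold lower number from compound 1 to compound 3 (0.31 log units; beyond the scatter) on this scale. Compound 4 `COc1cc(OCc2cccc(-c3ccc(C#N)cc3)c2)c2cc(-c3cn4nc(OC)sc4n3)oc2c1` has 4-cyanophenyl in place of 5-methoxypyridin-2-yl on an aromatic carbon and carries a nitrile, as compound 1 does. Read backwards, a 2.0-fold lower number from compound 1 to compound 3 (0.31 log units; beyond the scatter) points upward, yet compound 2 has no nitrile and a 1.1-fold lower number from compound 1 to compound 2 (0.03 log units; within the scatter) stays small. Going by the values given here, no measured compound shows the ring of carbon only. A modest upward step is therefore expected (a 1.7-fold higher number from compound 3 to compound 4 (0.23 log units; within the scatter)) and it may not clear the scatter. For compound 4 the estimate in this assay is 1.3 h with an expected range between 0.7 h and 2.4 h on repeat measurement.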

Compound 4, half-life: > 2 h
Compound 4 was reported as a limit (the forecaster's own chance of this, stated with the estimate: 2%); at least 1.5-fold (0.18 log units) between middle value and limit.
By their numbers in this assay, from the lowest: compounds 3, 2 and 1 (each within the scatter of the next, the first and the last beyond it). At a limit, above all of these: compound 4.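

In this assay, a ring of carbon only carrying a nitrile, the only such ring among the compounds shown, gives an at least 2.6-fold higher number from compound 3 to compound 4 (0.41 log units; beyond the scatter). Against the two other rings, the floors an at least 1.3-fold higher number from compound 2 to compound 4 (0.13 log units; that floor lies within the scatter) and an at least 1.2-fold higher number from compound 1 to compound 4 (0.10 log units; that floor lies within the scatter) do not separate compound 4 from compound 2 or compound 1. Compound 4 stands at a limit, not a number: the limit of > 2 h in this assay, at which 1 of the 4 values shown sits.

Going by these compounds, how far compound 4 lies past that limit stays open, as does whether the nitrile or the ring of carbon only carries the step. On these data alone, what an amine or a carboxylic acid in place of the nitrile on that ring would give also stays open.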